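The compounds below may be only part of what the source reports. "The series", "measured", "known", "first", "only" and "open" are said of these compounds alone.

Working notes on the series. Compound 1 `CC(C)(C)[C@@H](N)C(=O)NCc1ccc(COc2cccc(F)c2)cc1` and compound 2 `CC(C)(C)[C@@H](N)C(=O)NCc1ccc(Cl)cc1` share the same amino-amide core and are both characterised in a functional assay on the whole organism (strain albino Sprague-Dawley) with Rattus norvegicus as the target, in the maximal electroshock model; on this read-out higher numbers stand for an effect only at larger amounts of compound and lower numbers for an effect already at smaller amounts. In this assay compound 1 gives 30 mg/kg, and compound 2 gives 30 mg/kg; the two values are level at the digits recorded, so compound 1 stands at the same point as its nearest neighbour, compound 2, within the scatter.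

Compound 3 `CC(C)[C@@H](N)C(=O)NCc1ccc(COc2cccc(F)c2)cc1` has not been measured. It differs from compound 1 by hydrogen in place of methyl on a saturated chain carbon bound to three saturated chain carbons, or tert-butyl to isopropyl when read one bond further out. Going by the values given here, no measured pair carries this change, so its size is open. A modest step toward larger doses beyond the scatter is expected for compound 3, of the size a 2.0-fold higher number from compound 1 to compound 3 (0.30 log units; within the scatter). Compound 3 is therefore estimated at 60 mg/kg, with a range from 30 mg/kg to 150 mg/kg.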

Compound 3, dose for half-maximal effect: < 30 mg/kg
Compound 3: a limit, no number; the forecaster's own chance of this, stated with the estimate: 15%; at least 2.0-fold (0.30 log units) between middle value and limit.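

In this assay compound 3 gives < 30 mg/kg, which is a limit of the assay and not a number. Going by these compounds alone, this is the first measured pair at this position, and tert-butyl to isopropyl gives a number no higher from compound 1 to compound 3 (the limit leaves the size open), so the tert-butyl group is not needed to keep the effect at the dose level of compound 1. How far the dose level moves cannot be read from this pair: the limit of < 30 mg/kg in this assay, at which 1 of the 3 values shown sits.

On these data alone, whether the same change behaves alike on the 4-chlorobenzyl amide of compound 2 stays open, since only the 3-fluorophenoxymethyl side of the series carries it. Also open, as far as these compounds go, is how an ethyl, a cyclopropyl or a hydroxymethyl group would read at this place, and whether the isopropyl group is the best of such chains.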